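A few compounds are considered here, and "the series" means these few. Any claim that something is new, unique, unknown or untested is made for them only; others in the source may bear on it.

Measured compounds:
- compound 1 `CN(C)CCn1cnnc1-c1cc(Oc2ccc(NC(=O)N/N=C/c3c[nH]c4ccccc34)cc2F)ccn1`: 790 nM
- compound 2 `CN(C)CCn1cnnc1-c1cc(Oc2ccc(NC(=O)N/N=C/c3ccccc3)cc2F)ccn1`: 2730 nM
- compound 3 `CN(C)CCn1cnnc1-c1cc(Oc2ccc(NC(=O)N/N=C/c3ccc(F)cc3F)cc2F)ccn1`: 810 nM

In a functional assay on MKN-45 cells (Homo sapiens) for cytotoxicity, read by MTT assay, with a stated time of 72 h (a lower number here means a stronger inhibitor, a higher number a weaker inhibitor), compound 3 stands second highest of the three numbers, with compound 1 at an equal level and compound 2 further off: a 3.4-fold lower number from compound 2 to compound 3 (0.53 log units; beyond the scatter). The step to compound 4 `CN(C)CCn1cnnc1-c1cc(Oc2ccc(NC(=O)N/N=C/c3cccc(Br)c3)cc2F)ccn1` is 3-bromophenyl in place of 2,4-difluorophenyl on a carbon with a double bond to nitrogen. Among the measured compounds shown here, the steps that bear on it are the ones at the same carbon: a 3.5-fold higher number from compound 1 to compound 2 (0.54 log units; beyond the scatter) and a 3.4-fold lower number from compound 2 to compound 3 (0.53 log units; beyond the scatter), both modest, while a 1.0-fold higher number from compound 1 to compound 3 (0.01 log units; within the scatter). Replacing one substituted phenyl by another is expected to move the number little, though a slight rise toward the level of compound 2 is possible; the step is estimated as a 1.5-fold higher number from compound 3 to compound 4 (0.17 log units; within the scatter). Compound 4 is therefore expected to give 1200 nM, with a range from 500 nM to 3000 nM.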

Compound 4, half-maximal inhibitory concentration: 450 nM
Compound 4: the middle estimate sits 2.7-fold (0.43 log units) above what was measured; measured number below the stated range.
By their numbers in this assay, from the lowest: compounds 4, 1 and 3 (each within the scatter of the next); then compound 2.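

In this assay, bromo in place of hydrogen on an aromatic carbon gives a 6.1-fold lower number from compound 2 to compound 4 (0.78 log units; beyond the scatter) and thus shows that a single halogen atom on the phenyl is enough to separate a compound from compound 2. The 3-bromophenyl group cannot be told apart from the other two groups, with a 1.8-fold lower number from compound 3 to compound 4 (0.26 log units; within the scatter) and a 1.8-fold lower number from compound 1 to compound 4 (0.24 log units; within the scatter), so three different groups at this carbon now share one level. Nothing measured here explains these steps. The compounds shown leave open whether a 3-chlorophenyl or 4-bromophenyl group would match the 3-bromophenyl group. Going by these compounds, whether a phenyl carrying an amine or a carboxylic acid would hold this level also stays open.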